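Propyl Series: Swapping the Phenoxy Ring Substituent

A few compounds are considered here, and "the series" means these few. Any claim that something is new, unique, unknown or untested is made for them only; others in the source may bear on it.

Among the compounds with values here, compound 3 `CCCN1CCN(c2ccc(S(=O)(=O)Oc3ccccc3C)cc2)C1=O` is one of three compounds measured in a functional assay on MCF7 cells (Homo sapiens) for antiproliferative activity, read by sulforhodamine B assay, with a stated time of 48 h; on this read-out lower numbers stand for stronger inhibition and higher numbers for weaker inhibition. For compound 3 the result is only a limit, > 100000 nM. Compound 1 `Cc1ccccc1OS(=O)(=O)c1ccc(N2CCN(C)C2=O)cc1` gives 5600 nM, and compound 2 `CCN1CCN(c2ccc(S(=O)(=O)Oc3cccc(OC)c3)cc2)C1=O` gives 14000 nM. Within the data shown here, the one measured step in this set, an at least 17-fold higher number from compound 1 to compound 3 (1.25 log units; beyond the scatter), runs toward weaker inhibition and ends at the limit of > 100000 nM in this assay, at which 1 of the 3 values shown sits. Compound 4 `CCCN1CCN(c2ccc(S(=O)(=O)Oc3ccc(OC)cc3)cc2)C1=O` differs from compound 3 by 4-methoxyphenyl in place of 2-methylphenyl on an oxygen. Among the measured compounds shown here, no measured step covers this change, and compound 2 differs from compound 4 in more than one place. Compound 4 is therefore expected to remain weak, with an estimated 80000 nM and a range from 20000 nM to 300000 nM. The expected step is an at least 1.2-fold lower number from compound 3 to compound 4 (0.09 log units; that floor lies within the scatter), which is not expected to exceed the scatter.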

Compound 4, half-maximal inhibitory concentration: 20000 nM
Estimate against measurement, compound 4: 4.0-fold (0.60 log units) above, within the range that was stated.
By their numbers in this assay, from the lowest: compound 1; then compounds 2 and 4 (each within the scatter of the next). At a limit, above all of these: compound 3.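

Within the data shown here, putting 4-methoxyphenyl in place of 2-methylphenyl on the oxygen bound to the sulfonyl sulfur gives an at least 5.0-fold lower number from compound 3 to compound 4 (0.69 log units; beyond the scatter) in this assay and is the first measured step at this place. It shows that a propyl compound can give a measurable number, so the propyl chain alone does not put a compound at the limit. The true size of the step stays unknown, as the value of compound 3 is only a limit: the limit of > 100000 nM in this assay, at which 1 of the 4 values shown sits.

The compounds shown leave open whether the step belongs to the methoxy group or to where it sits, which 4-methylphenyl or 2-methoxyphenyl on the same oxygen would separate. They also leave open how a longer chain such as butyl would fare with 4-methoxyphenyl.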